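From Methoxy to Trifluoromethoxy: An Unmeasured Step

This account rests on a few compounds, and the source may have more. Where it says the series, first, only, none or still open, it means among the compounds named here.

Three amides on a shared core have been measured so far. In a functional assay on A549 cells (Homo sapiens) for cytotoxicity, read by MTT assay (on this read-out lower numbers stand for stronger inhibition and higher numbers for weaker inhibition), compound 1 (`CCn1cc(C(=O)Nc2ccccc2)c(=O)c2cc(F)c(N3CCNC(C)C3)c(F)c21`) gives 39300 nM as the highest number of the three, compound 2 (`CCn1cc(C(=O)Nc2ccccc2N)c(=O)c2cc(F)c(N3CCNC(C)C3)c(F)c21`) gives 5900 nM and compound 3 (`CCn1cc(C(=O)Nc2ccc(OC)cc2)c(=O)c2cc(F)c(N3CCNC(C)C3)c(F)c21`) gives 9700 nM on the same scale. Compound 3 thus stands within the scatter of compound 2 and clearly under compound 1. Compound 4 (`CCn1cc(C(=O)Nc2ccc(OC(F)(F)F)cc2)c(=O)c2cc(F)c(N3CCNC(C)C3)c(F)c21`) differs from compound 3 in one place, with trifluoromethyl in place of methyl on an oxygen on an aromatic ring. Within the data shown here, no measured step makes this exact change. The closest evidence is methoxy in place of hydrogen on an aromatic carbon, seen as a 4.1-fold lower number from compound 1 to compound 3 (0.61 log units; beyond the scatter) in this assay and comparable to the amino step, a 6.7-fold lower number from compound 1 to compound 2 (0.82 log units; beyond the scatter) in the same read-out. Since compound 4 keeps the oxygen on the aromatic ring, no shift beyond the scatter is expected, and the estimate is a 1.1-fold higher number from compound 3 to compound 4 (0.05 log units; within the scatter) in this assay at most a slight rise. Compound 4 is estimated at 11000 nM with a range of 4500 nM to 28000 nM as expected bounds.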

Compound 4, half-maximal inhibitory concentration: 1320 nM
Beside the measured number, compound 4's estimate is 8.3-fold (0.92 log units) above it; measured number below the stated range.
By their numbers in this assay, from the lowest: compound 4; then compounds 2 and 3 (each within the scatter of the next); then compound 1.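

In this assay the oxygen on the aromatic ring does not settle the outcome by itself: trifluoromethyl in place of methyl on that oxygen gives a 7.3-fold lower number from compound 3 to compound 4 (0.87 log units; beyond the scatter) and so shows that the group carried by the oxygen matters at this position. Compound 2 and compound 3 stood within the scatter of each other, but the new group separates the series, with a 4.5-fold lower number from compound 2 to compound 4 (0.65 log units; beyond the scatter) and a 30-fold lower number from compound 1 to compound 4 (1.47 log units; beyond the scatter) as the largest step seen so far, leaving compound 4 with the lowest number of the four. Nothing measured here accounts for this change.

From the compounds shown here alone, what a difluoromethoxy group or an ethoxy group would give on the same oxygen remains open. So does whether a trifluoromethyl group placed directly on the aromatic carbon, without the oxygen, would match trifluoromethoxy.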